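Propyl for Isopropyl on the Carbamate of Compound 1

The source may hold more compounds than are shown below. What is called first, only, known or untested is meant among the compounds shown, and "the series" means these compounds.

Measured compounds, with their values in a functional assay on HCT-116 cells (Homo sapiens) for cytotoxicity, read by MTT assay; on this read-out lower numbers stand for stronger inhibition and higher numbers for weaker inhibition:
- compound 1 `CCc1cc(S(=O)(=O)N2C[C@H](c3ccccc3)NC2=O)ccc1NC(=O)OC(C)C`: compound 1 gives 60 nM
- compound 2 `CCOC(=O)Nc1c(C)cc(S(=O)(=O)N2C[C@H](c3ccccc3)NC2=O)cc1C`: compound 2 gives > 10000 nM, a limit of the assay
- compound 3 `CCOC(=O)Nc1ccc(S(=O)(=O)N2C(=O)N[C@@H](c3ccccc3)C2C)cc1C`: compound 3 gives 5500 nM

Compound 1 holds the lowest of the two numbers reported. Its nearest neighbour among the numbers is compound 3, whose value lies far higher, a gap beyond the usual scatter. Compound 2 sits at a limit of this assay, (the limit of > 10000 nM in this assay, at which 1 of the 3 values shown sits), so it contributes no number.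

Compound 4 `CCCOC(=O)Nc1ccc(S(=O)(=O)N2C[C@H](c3ccccc3)NC2=O)cc1CC` has not yet been measured. It differs from compound 1 only in one place: propyl in place of isopropyl on an oxygen next to a carbonyl group. Within the data shown here, no pair of measured compounds shows this kind of change, so nothing in the data fixes its size. The exchange of one three-carbon chain for another is expected to move the value little, and the step from compound 1 to compound 4, a 1.5-fold higher number from compound 1 to compound 4 (0.18 log units; within the scatter), is expected to stay within or close to the scatter. Compound 4 is therefore estimated at 90 nM, with a range from 25 nM to 400 nM.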

Compound 4, half-maximal inhibitory concentration: 60 nM
Compound 4: the middle estimate sits 1.5-fold (0.18 log units) above what was measured; measured number inside the range.
By their numbers in this assay, from the lowest: compounds 1 and 4 (each within the scatter of the next); then compound 3. At a limit, above all of these: compound 2.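

Putting propyl in place of isopropyl on an oxygen next to a carbonyl group gives no change at the digits printed from compound 1 to compound 4 (within the scatter) in this assay, the first step shown between compounds that differ in one place. For this pair, then, the position holds its value with either chain, so the arrangement of these carbons makes no difference beyond the scatter here. Nothing shown accounts for this outcome.

On these data alone, whether the value would also hold with a butyl chain, a longer chain, a cyclopropyl ring or a benzyl group on this oxygen remains open. This single step also leaves open whether an amine or a carboxylic acid at the end of the chain would be tolerated.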